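A few compounds are considered here, and "the series" means these few. Any claim that something is new, unique, unknown or untested is made for them only; others in the source may bear on it.

Measured compounds:
compound 1, `CC(c1ccc(-c2ccccc2)c(F)c1)c1nnc2n1N=C(c1ccc(OC(F)(F)F)cc1)CS2`: 5400 nM
compound 2, `COc1ccc2cc(C(C)c3nnc4n3N=C(c3ccc(Cl)cc3Cl)CS4)ccc2c1`: 14000 nM
compound 3, `COc1ccc(C2=Nn3c(nnc3C(C)c3ccc4cc(OC)ccc4c3)SC2)cc1`: 6500 nM

In a functional assay on HCT-116 cells (Homo sapiens) for inhibition, read by sulforhodamine B assay, with a stated time of 72 h (on this read-out lower numbers stand for stronger inhibition and higher numbers for weaker inhibition), compound 1 gives the lowest of the three numbers. Compound 3 is nearest, within the scatter of compound 1, while compound 2 is furthest, beyond it. For the measured compounds named here, the one measured step, a 2.2-fold lower number from compound 2 to compound 3 (0.33 log units; beyond the scatter), swaps the aryl group on a carbon with a double bond to nitrogen and was modest.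

Compound 4, `CC(c1ccc(-c2ccccc2)c(F)c1)c1nnc2n1N=C(c1ccc(Br)cc1)CS2`, differs from compound 1 in one place: bromo in place of trifluoromethoxy on an aromatic carbon. Going by the values given here, that change touches the same aryl group that moved between compound 2 and compound 3, so the step from compound 2 to compound 3 is the only guide, and it was small. Among the compounds with values here, no measured pair shows bromo against trifluoromethoxy directly, so the direction is open. A step of about the same size or smaller is expected, a 1.2-fold higher number from compound 1 to compound 4 (0.08 log units; within the scatter), leaning slightly toward a higher number because compound 2, the aryl bearing halogens, gave 14000 nM, the highest of the three. Compound 4 is therefore estimated at 6500 nM, with a range from 2500 nM to 16000 nM.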

Compound 4, half-maximal inhibitory concentration: 7100 nM
For compound 4 the middle estimate is 1.1-fold (0.04 log units) below the measured one, within the range that was stated.
By their numbers in this assay, from the lowest: compounds 1, 3, 4 and 2 (each within the scatter of the next, the first and the last beyond it).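

In this assay, for the compounds shown here, the result gives the first direct reading of the 4-(trifluoromethoxy)phenyl to 4-bromophenyl change, with a 1.3-fold higher number from compound 1 to compound 4 (0.12 log units; within the scatter). At this aromatic carbon, para to a large group, a substituent of five heavy atoms including one hydrogen-bond acceptor gives way to a single bromine with no such acceptor, and the read-out does not move beyond the usual scatter, so this pair shows that the position tolerates this particular exchange, unlike the earlier aryl change with a different group elsewhere in the molecule, which showed a 2.2-fold lower number from compound 2 to compound 3 (0.33 log units; beyond the scatter). Nothing measured here accounts for why the two substituents read alike, and no supporting data bear on the result.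

The compounds shown leave open whether this tolerance extends to quite different groups on the same aromatic carbon, such as an amine, a carboxylic acid or a longer alkoxy chain. They also leave open whether the 4-methoxyphenyl and 2,4-dichlorophenyl groups would keep their difference when paired with the other side group carried by compound 1 and compound 4.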